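Swapping trifluoromethyl for carboxy on the benzoyl ring

A few compounds are considered here, and "the series" means these few. Any claim that something is new, unique, unknown or untested is made for them only; others in the source may bear on it.

Compound 1 `O=C(/C(=C\c1ccc(O)c([N+](=O)[O-])c1)SCc1ccc(Br)cc1)c1ccc(C(F)(F)F)cc1` carries a trifluoromethyl group on its benzoyl ring. In a functional assay on DU-145 cells (Homo sapiens) for inhibition, read by trypan blue exclusion, with a stated time of 96 h (on this read-out lower numbers stand for stronger inhibition of growth and higher numbers for weaker inhibition of growth), compound 1 gives 10000 nM. Compound 2 `O=C(/C(=C\c1ccc([N+](=O)[O-])c(O)c1)SCc1ccc(Br)cc1)c1ccc(C(F)(F)F)cc1` shows 1000 nM, and compound 3 `CN(C)c1ccc(/C=C(/SCc2ccc(F)cc2)C(=O)c2ccc(C(=O)O)cc2)cc1` shows 10000 nM. Within the data shown here, compound 1 therefore sits level with compound 3, and the two together are the highest numbers of the three, while the only step that stands out is a 10-fold lower number from compound 1 to compound 2 (1.00 log units; beyond the scatter).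

Compound 4 `O=C(O)c1ccc(C(=O)/C(=C\c2ccc(O)c([N+](=O)[O-])c2)SCc2ccc(Br)cc2)cc1` is compound 1 with carboxy in place of trifluoromethyl on an aromatic carbon. Among the measured compounds shown here, no measured pair repeats this change, so the only pointer is that compound 3 also carries a carboxyphenyl group and yields the same number as compound 1, though compound 3 differs in several further places. On this thin basis a step of no change at the digits printed from compound 1 to compound 4 (within the scatter) is expected, that is no change beyond the scatter. Compound 4 is estimated at 10000 nM in this assay, with a range of 3000 nM to 30000 nM.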

Compound 4, concentration for 50% growth inhibition: 50000 nM
For compound 4 the middle estimate is 5.0-fold (0.70 log units) below the measured one; measured number above the stated range.
By their numbers in this assay, from the lowest: compound 2; then compounds 1 and 3 (each within the scatter of the next); then compound 4.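

In this assay, carboxy in place of trifluoromethyl on this aromatic carbon brings a 5.0-fold higher number from compound 1 to compound 4 (0.70 log units; beyond the scatter), which means weaker inhibition of growth. Among these compounds, this gives the first direct reading at this position of the benzoyl ring and shows that the group there matters, whereas the only earlier step concerned the arrangement of hydroxy and nitro on the other ring. No independent measurement is available to explain the size or direction of this step.

One pair cannot show whether the loss belongs to carboxy alone or would also appear with a methyl ester, an amide or a nitrile on the same carbon. On these data alone, it also remains open whether the same swap would bring a similar step when made on compound 2, which carries 3-hydroxy-4-nitrophenyl.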